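The source may report more compounds than this note shows. Statements on the series, on what has been measured and on what is new or still open speak of the compounds shown alone.

Working notes on the series. The shared core carries a benzylsulfanyl group whose aryl part is varied. In a functional assay on MCF7 cells (Homo sapiens) for cytotoxicity, read by MTT assay, with a stated time of 72 h (on this read-out higher numbers stand for weaker inhibition and lower numbers for stronger inhibition), compound 1 `Cc1cc(S(=O)(=O)/N=C(\N)n2nccc2-c2ccccc2)c(SCc2cccc(Cl)c2)cc1Cl` gives 88000 nM. Compound 2 `Cc1cc(-c2ccccc2)n(/C(N)=N/S(=O)(=O)c2cc(C)c(Cl)cc2SCc2cccc(C(F)(F)F)c2)n1`, whose core is not identical to that of the other two, gives 41000 nM in this assay. Compound 3 `Cc1cc(S(=O)(=O)/N=C(\N)n2nccc2-c2ccccc2)c(SCc2ccccc2C)cc1Cl` gives 23000 nM in this assay, the lowest of the three numbers; its gap to compound 1 is beyond the scatter, its gap to compound 2 within it, so no order between compound 3 and compound 2 is claimed. Among the measured compounds shown here, the only measured step on the aryl part is a 3.8-fold lower number from compound 1 to compound 3 (0.58 log units; beyond the scatter).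

Compound 4 `Cc1cc(S(=O)(=O)/N=C(\N)n2nccc2-c2ccccc2)c(SCc2cccc(C(F)(F)F)c2)cc1Cl` is not yet measured. It differs from compound 3 thus: 3-(trifluoromethyl)phenyl in place of 2-methylphenyl on a saturated chain carbon bound to a sulfur. For the measured compounds named here, no measured step covers exactly this exchange. The step of a 3.8-fold lower number from compound 1 to compound 3 (0.58 log units; beyond the scatter) shows that changing the aryl substituent shifts the number by a modest amount. Compound 2 carries the same 3-(trifluoromethyl)benzyl group on a closely related core and gives 41000 nM, within the scatter of compound 3. For compound 4 a step of a 1.7-fold higher number from compound 3 to compound 4 (0.24 log units; within the scatter) is therefore expected. Compound 4 is estimated at 40000 nM, with a range from 15000 nM to 110000 nM.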

Compound 4, half-maximal inhibitory concentration: 17000 nM
Compound 4: the middle estimate sits 2.4-fold (0.37 log units) above what was measured; the range from low to high includes it.
By their numbers in this assay, from the lowest: compounds 4, 3 and 2 (each within the scatter of the next, the first and the last beyond it); then compound 1.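

In this assay the step of a 1.4-fold lower number from compound 3 to compound 4 (0.13 log units; within the scatter) lies within the scatter, so on a saturated chain carbon bound to a sulfur, 3-(trifluoromethyl)phenyl and 2-methylphenyl cannot be told apart on the shared core. Taken with a 3.8-fold lower number from compound 1 to compound 3 (0.58 log units; beyond the scatter) and with the step of a 5.2-fold lower number from compound 1 to compound 4 (0.71 log units; beyond the scatter), both beyond the scatter, this leaves 3-chlorophenyl as the one aryl group of the three on the shared core that stands apart, with the highest number, while the other two do not separate. Among the compounds shown here, the step of a 2.4-fold lower number from compound 2 to compound 4 (0.38 log units; beyond the scatter), also beyond the scatter, is the first reading of a change outside the aryl part: hydrogen in place of methyl on an aromatic carbon moves the number by a modest amount, so the 3-(trifluoromethyl)benzyl group does not fix the number by itself.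

Going by these compounds, whether an amine or a carboxylic acid on the aryl part, or a longer chain in place of the benzyl group, would shift the number on this core remains open. No evidence at hand accounts for the size of any of these steps.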